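The source may hold more compounds than are shown below. What is called first, only, known or untested is meant among the compounds shown, and "the series" means these compounds.

The series shares the core of compound 1, `CCCCCOc1ccc(C(=O)N(C(=S)OCCN2C(=O)c3ccccc3C2=O)c2ccc(F)cc2)cc1`, with compound 2 `Cc1ccccc1C(=O)N(C(=S)OCCN1C(=O)c2ccccc2C1=O)c1ccc(Cl)cc1` and compound 3 `Cc1ccc(N(C(=O)c2ccccc2C)C(=S)OCCN2C(=O)c3ccccc3C2=O)cc1` varying the two aryl groups on either side of it. In an ADME assay on MT4 cells (Homo sapiens) for cytotoxicity, read by MTT assay (a higher number here means that more compound is tolerated, a lower number that less compound is tolerated), compound 1 gives > 100000 nM, which is a limit of the assay and not a number. Compound 2 gives 21000 nM in this assay. Compound 3 gives > 100000 nM, again a limit of the assay rather than a measured number. Within the data shown here, only one step between compounds differing in one place is known, and it is open-ended because an at least 4.7-fold higher number from compound 2 to compound 3 (0.67 log units; beyond the scatter) runs into the limit. Compound 3 therefore stands at the top of what this assay can report, and the limit of > 100000 nM in this assay, at which 2 of the 3 values shown sit, shows that most values of the series sit there as well.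

Compound 4, `COc1cccc(OC)c1C(=O)N(C(=S)OCCN1C(=O)c2ccccc2C1=O)c1ccc(C)cc1`, is the next step: 2,6-dimethoxyphenyl in place of 2-methylphenyl on a carbonyl carbon. Among the measured compounds shown here, no measured step concerns the group on the carbonyl carbon; the single known step concerns the other aromatic ring. There is thus no basis for a move in either direction beyond the scatter, and the starting point is itself a limit. The expected step of a number no higher from compound 3 to compound 4 (the limit leaves the size open) is flat, with a fair chance that only a limit is reported again. The estimate for compound 4 in this assay is 100000 nM, within a range of 30000 nM to 300000 nM.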

Compound 4, half-maximal cytotoxic concentration: 36000 nM
Compound 4: middle estimate off by 2.8-fold (0.44 log units), on the high side; low and high end bracket the measured number.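

Compared with the earlier compounds, the group on the carbonyl carbon now has a measured effect in this assay: 2,6-dimethoxyphenyl in place of 2-methylphenyl gives an at least 2.7-fold lower number from compound 3 to compound 4 (0.44 log units; beyond the scatter) on the same amide-type nitrogen, so tolerance depends on this position as well as on the other aromatic ring, the site of the only earlier step. The change also moves the series from the ceiling of the read-out to a measurable number at this position, which gives later changes on this carbonyl carbon a value to be compared against, unlike the starting point. From the compounds shown here alone, the true size of the step stays open-ended because compound 3 stands at a limit of the assay and not at a number: the limit of > 100000 nM in this assay, at which 2 of the 4 values shown sit.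

A single step cannot tell whether the lower number goes with the methoxy groups themselves, with how many of them are present, or with the loss of the methyl group. Going by these compounds, how a single methoxy group, an amine or a carboxylic acid on this aryl group would read in this assay remains open, as does whether the step holds with other groups on the second aromatic ring.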